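This account rests on a few compounds, and the source may have more. Where it says the series, first, only, none or still open, it means among the compounds named here.

Measured compounds:
- Compound 1 `CCCc1nc(-c2ccccc2)c(CNCCCN2CCN(c3ccccc3Cl)CC2)o1`, which in an assay on HEK293 cells for inhibition of Voltage-dependent T-type calcium channel subunit alpha-1G (Homo sapiens), read by patch clamp (on this read-out lower numbers stand for stronger inhibition and higher numbers for weaker inhibition), gives 2800 nM
- Compound 2 `CCCc1nc(-c2ccccc2)c(CNCCN2CCN(c3ccc(OC)cc3)CC2)o1`, which in this assay gives 9200 nM

Of the two numbers recorded so far, compound 1 stands at the lower one; the number for compound 2 is higher by a margin that lies beyond the usual scatter of this assay. Within the data shown here, no single-point step between these two measured compounds has been recorded, since they differ in more than one place, so only the two values themselves can be compared.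

The step under consideration leads from compound 1 to compound 3 `CCCc1nc(-c2ccccc2)c(CNCCCN2CCN(c3ccccc3F)CC2)o1`. The change is fluoro in place of chloro on an aromatic carbon. Nothing else in the molecule moves.

Compound 3 has not yet been measured. Since no comparable exchange exists among the measured compounds, the expectation rests on the structural change alone. A modest weakening is expected, with the step of a 1.6-fold higher number from compound 1 to compound 3 (0.21 log units; within the scatter) close to the edge of the scatter rather than far beyond it. For compound 3 the estimate in this assay is 4500 nM, with a range from 1800 nM to 11000 nM.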

Compound 3, half-maximal inhibitory concentration: 16100 nM
Beside the measured number, compound 3's estimate is 3.6-fold (0.55 log units) below it; the whole stated range lies below it.
By their numbers in this assay, from the lowest: compound 1; then compounds 2 and 3 (each within the scatter of the next).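

Among these compounds, the exchange of chloro for fluoro, on an aromatic carbon ortho to a large group, gives the first change at a single place in this assay, and the step from 2-chlorophenyl to 2-fluorophenyl is a 5.8-fold higher number from compound 1 to compound 3 (0.76 log units; beyond the scatter) in size. The position therefore responds to a swap of one halogen for another, even though the heavy-atom count stays the same and no hydrogen-bond donor or acceptor enters or leaves, and the chloro of compound 1 gives the lower number of this pair. The compounds shown offer no measurement that accounts for the size of this step, and no independent data bear on it.

As far as these compounds go, with only these two halogens compared at this place, it remains open whether a bromo, methyl or trifluoromethyl group there would give a lower number than chloro, or whether a plain hydrogen would give a higher one. From the compounds shown here alone, it also remains open whether the same exchange of chloro for fluoro would produce a step of similar size on a core carrying a longer chain.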